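Series notes: halogenated aryl on the piperazine nitrogen

The source may report more compounds than this note shows. Statements on the series, on what has been measured and on what is new or still open speak of the compounds shown alone.

Compound 2 `CCC1(CCCCN2CCN(c3ccccc3)CC2)C(=O)Nc2ccccc21` is measured in an assay on CHO cells for displacement of a labelled ligand from 5-hydroxytryptamine receptor 7 (Homo sapiens) (on this read-out lower numbers stand for stronger inhibition and higher numbers for weaker inhibition), where compound 2 gives 2.07 nM. Compound 1 `CCC1(CCCCCN2CCN(c3cccc(Cl)c3)CC2)C(=O)Nc2ccccc21` gives 1.45 nM in this assay. The two values lie within the usual scatter of each other, so on these numbers compound 2 cannot be set apart from compound 1.

Compound 3 `CCC1(CCCCN2CCN(c3ccc(F)c(Cl)c3)CC2)C(=O)Nc2ccccc21` has not yet been measured in this assay. It differs from compound 2 in one place: 3-chloro-4-fluorophenyl in place of phenyl on an amine nitrogen in a ring. Among the measured compounds shown here, no measured pair shows this change on its own, so its size is not known from the data; neither compound 1 nor compound 2 carries the group that enters. The expected step is a 1.3-fold lower number from compound 2 to compound 3 (0.11 log units; within the scatter), small and with no direction beyond the scatter claimed. Compound 3 is estimated at 1.6 nM, in a range from 0.6 nM to 4.5 nM.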

Compound 3, inhibition constant: 0.6 nM
Estimate against measurement, compound 3: 2.7-fold (0.43 log units) above, within the range that was stated.
By their numbers in this assay, from the lowest: compound 3; then compounds 1 and 2 (each within the scatter of the next).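

In this assay, 3-chloro-4-fluorophenyl in place of phenyl on an amine nitrogen in a ring gives a 3.5-fold lower number from compound 2 to compound 3 (0.54 log units; beyond the scatter), so the number at this position responds to substitution on the aryl ring by more than the scatter. This single step covers the chlorine and the fluorine entering together, with the rest of compound 2 unchanged, and compound 1 differs from compound 3 in more than one place, so it adds no direct comparison. Nothing in the data on hand speaks to the origin of this step.

Going by these compounds, whether a lone chlorine or a lone fluorine on the phenyl ring would give a step of similar size remains open. On these data alone, the outcome with a methoxy group or a nitrile on that ring is also open.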